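This account rests on a few compounds, and the source may have more. Where it says the series, first, only, none or still open, it means among the compounds named here.

The measured compounds, each in a functional assay on NCI-H460 cells (Homo sapiens) for antiproliferative activity, read by MTT assay, with a stated time of 24 h; a higher number here means a weaker inhibitor, a lower number a stronger inhibitor:

Compound 1 `CC(=O)OCCc1c(C)[nH]c(=O)[nH]c1=O` gives a value that is a limit of the assay, > 100000 nM.
Compound 2 `COc1nc(C)c(CCOC(C)=O)c(OC)n1` gives 47000 nM.
Compound 3 `Cc1[nH]c(=O)[nH]c(=O)c1CCCl` gives a value that is likewise a limit, > 100000 nM.

Compounds 1 and 3 share a core and differ by a single change, (chloro in place of acetoxy on a saturated chain carbon, two bonds along the chain from an aromatic carbon). The step that the two limits leave unreadable from compound 1 to compound 3 cannot be sized because both sit at the limit of > 100000 nM in this assay, at which 2 of the 3 values shown sit. Compound 2 carries a different core; how it differs from compound 1 is not broken down here, and compound 2 is the only one of the three to give an actual number in this assay.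

Compound 4 `COc1nc(C)c(CCCl)c(OC)n1` stands to compound 2 as compound 3 stands to compound 1: the change is chloro in place of acetoxy on a saturated chain carbon, two bonds along the chain from an aromatic carbon, at the same place in the same words. Among the measured compounds shown here, since the only measured instance of this change is unreadable, nothing in the data fixes its size, and the expectation for compound 4 rests on compound 2 alone, whose value of 47000 nM is the one number available. Compound 4 is therefore expected to lie near compound 2, with an estimated step of a 1.1-fold higher number from compound 2 to compound 4 (0.03 log units; within the scatter). Compound 4 is estimated at 50000 nM, between 15000 nM and 150000 nM.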

Compound 4, half-maximal inhibitory concentration: > 100000 nM
Compound 4 gave a limit, no number (the forecaster's own chance of this, stated with the estimate: 35%); middle value at least 2.0-fold (0.30 log units) away from the limit.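

In this assay the change from acetoxy to chloro on the core of compound 2 reads as an at least 2.1-fold higher number from compound 2 to compound 4 (0.32 log units; beyond the scatter), a step beyond the scatter whose true size may be larger. Compound 4 gives > 100000 nM, which is a limit of the assay and not a number. The same change cannot be read on the core of compound 1, so the pair of compound 1 and compound 3 neither supports nor contradicts this step, and whether it carries from one core to the other stays unsettled, with both compounds of that pair at the limit: the limit of > 100000 nM in this assay, at which 3 of the 4 values shown sit.

The compounds shown leave open whether any other group in the place of acetoxy would match or improve on compound 2, which gives 47000 nM in this assay. From the compounds shown here alone, how an amine, a hydroxyl or a carboxylic acid in that place would read on either core remains unknown, as does the effect of a longer chain.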